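Bromothiophene swap on the hydroxycoumarin core

A few compounds are considered here, and "the series" means these few. Any claim that something is new, unique, unknown or untested is made for them only; others in the source may bear on it.

Measured compounds, an assay on CHO cells for displacement of a labelled ligand from transmembrane domain-containing protein TMIGD3 (Homo sapiens); on this read-out lower numbers stand for stronger inhibition and higher numbers for weaker inhibition:
Compound 1 `CC(=O)Oc1ccc2cc(-c3ccsc3)c(=O)oc2c1OC(C)=O` gives 3600 nM in this assay.
Compound 2 `CC(=O)Oc1ccc2cc(-c3cc(Br)cs3)c(=O)oc2c1OC(C)=O` reaches only the limit of this assay, > 100000 nM.
Compound 3 `O=c1oc2c(O)cccc2cc1-c1ccsc1` gives 2870 nM in this assay.

Compound 1 and compound 3 sit within the usual scatter of each other; how their two cores differ is not broken down here. From compound 1 to compound 2 the change is 4-bromothiophen-2-yl in place of thiophen-3-yl on an aromatic carbon, and the step is an at least 27-fold higher number from compound 1 to compound 2 (1.44 log units; beyond the scatter). The size of that step rests on (the limit of > 100000 nM in this assay, at which 1 of the 3 values shown sits), so its true extent is open; only its direction and its floor are known.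

Compound 4 `O=c1oc2c(O)cccc2cc1-c1cc(Br)cs1` is not yet measured. It carries the same change on the core of compound 3: 4-bromothiophen-2-yl in place of thiophen-3-yl on an aromatic carbon. The place is described in the same words for both pairs, so the change is the same, set on a different core.

Among the measured compounds shown here, the step from compound 3 to compound 4 is expected to be a 28-fold higher number from compound 3 to compound 4 (1.45 log units; beyond the scatter), large and in the same direction, because the only measured instance of this change is an at least 27-fold higher number from compound 1 to compound 2 (1.44 log units; beyond the scatter) and compound 3 starts close to compound 1. Compound 4 is therefore estimated at 80000 nM, with a range from 15000 nM to 400000 nM, and there is a fair chance that this assay again reports only a limit for compound 4.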

Compound 4, inhibition constant: 746 nM
Compound 4: middle estimate off by 110-fold (2.03 log units), on the high side; the measured number lies below the stated range.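

In this assay, 4-bromothiophen-2-yl in place of thiophen-3-yl gives a 3.8-fold lower number from compound 3 to compound 4 (0.59 log units; beyond the scatter), so on these two cores the change does not carry over in size or in direction: the same change on two cores in this assay, an at least 27-fold higher number (1.44 log units; beyond the scatter) from compound 1 to compound 2 and a 3.8-fold lower number (0.59 log units; beyond the scatter) from compound 3 to compound 4, at least 100-fold (2.02 log units) apart, beyond the scatter of two such steps

The value of compound 2 is a limit and not a number, so the earlier step has only a direction and a floor: the limit of > 100000 nM in this assay, at which 1 of the 4 values shown sits.

The two pairs show that the outcome of this change depended on the core here, and that a result on one core was a poor guide to the other, but they do not show which difference between the cores matters or how the change would behave on any further core.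

The change both moves the point of attachment of the thiophene and adds a bromine, and the compounds shown do not separate the two, so an unsubstituted thiophen-2-yl on each core would be the informative comparison. Among the compounds shown here, also open is whether a chlorine, a nitrile or a carboxylic acid in place of the bromine would follow compound 2 on the one core and compound 4 on the other.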